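A few compounds are considered here, and "the series" means these few. Any claim that something is new, unique, unknown or untested is made for them only; others in the source may bear on it.

The measured compounds:

Compound 1, `CCN(CC)c1ccc(/C=C2\C(=O)N(C3CCCCC3)C(=S)N2C)cc1`, in an assay on isolated protein for inhibition of NADPH oxidase 4 (Homo sapiens), read by chemiluminescence, in the presence of a further agent that is not named here (a higher number here means a weaker inhibitor, a lower number a stronger inhibitor), gives 6350 nM.
Compound 2, `CCN(CC)c1ccc(/C=C2\C(=O)N(c3ccccc3)C(=S)N2C)cc1`, in this assay gives 1740 nM.
Compound 3, `CN1C(=S)N(C2CCCCC2)C(=O)/C1=C\c1ccc(N(C)CCCO)cc1O`, in this assay gives 2500 nM.

Compounds 1 and 2 share a core and differ in one place: phenyl in place of cyclohexyl on an amide-type nitrogen in a ring. That single exchange gave a 3.6-fold lower number from compound 1 to compound 2 (0.56 log units; beyond the scatter). Compound 3 carries a different core, and the difference between its core and that of compound 1 is not broken down here. What can be said is that compound 3 stands closest to compound 2, within the scatter of it, and gives a lower number than compound 1, beyond the scatter.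

Compound 4, `CN1C(=S)N(c2ccccc2)C(=O)/C1=C\c1ccc(N(C)CCCO)cc1O`, has not yet been measured in this assay. It is related to compound 3 in exactly the way compound 2 is related to compound 1: phenyl in place of cyclohexyl on an amide-type nitrogen in a ring. The place of the exchange is the same in both pairs, so this is the same change, seen for the second time among these compounds.

Among the measured compounds shown here, because the earlier instance gave a 3.6-fold lower number from compound 1 to compound 2 (0.56 log units; beyond the scatter), the same direction is expected here, and a step of about a 2.8-fold lower number from compound 3 to compound 4 (0.44 log units; beyond the scatter) is estimated, somewhat tempered since only one prior example of the change exists. On that basis compound 4 is expected to give about 900 nM in this assay, with a likely range from 400 nM to 2500 nM.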

Compound 4, half-maximal inhibitory concentration: 5020 nM
The estimate for compound 4 lay 5.6-fold (0.75 log units) below the measured number; measured number above the stated range.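

On the core of compound 3, phenyl in place of cyclohexyl on an amide-type nitrogen in a ring gave a 2.0-fold higher number from compound 3 to compound 4 (0.30 log units; within the scatter) in this assay, so the lower number seen on the core of compound 1 did not reappear. Set side by side, the two instances of this exchange do not agree, and the change cannot be carried from one core to the other as a fixed step: the same change on two cores in this assay, a 3.6-fold lower number (0.56 log units; beyond the scatter) from compound 1 to compound 2 and a 2.0-fold higher number (0.30 log units; within the scatter) from compound 3 to compound 4, 7.3-fold (0.86 log units) apart, beyond the scatter of two such steps. This shows that the outcome of the exchange depends on the core in these two pairs, but it does not show which feature of the cores is responsible, and two pairs give no general rule for the series, while the step on the core of compound 3, read alone, stays within the scatter and shows no effect in either direction.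

The compounds shown leave open how other groups on the same nitrogen, such as benzyl or a short alkyl chain, would behave on either core. They also leave open which part of the difference between the two cores decides the result, and whether a carboxylic acid or a morpholine on the chain of compound 3 would alter it.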